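Methyl on an aromatic nitrogen of compound 2

The source may hold more compounds than are shown below. What is called first, only, known or untested is meant among the compounds shown, and "the series" means these compounds.

Measured in a functional assay on HCT-116 cells (Homo sapiens) for antiproliferative activity, read by MTT assay, with a stated time of 48 h; on this read-out higher numbers stand for weaker inhibition and lower numbers for stronger inhibition:
- compound 1 `COc1cc(-c2nnc3c(OC)cc(-c4ccc5[nH]ccc5c4)cn23)cc(OC)c1OC`: 108 nM
- compound 2 `COc1cc(-c2nnc3c(OC4COC4)cc(-c4ccc5[nH]ccc5c4)cn23)cc(OC)c1OC`: 5370 nM
- compound 3 `COc1cc(-c2nnc3c(OC4CN(C(C)(C)C)C4)cc(-c4ccc5[nH]ccc5c4)cn23)cc(OC)c1OC`: > 10000 nM (a limit of the assay, not a number)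

Of the two true numbers in this assay, compound 2 has the higher, 5370 nM. The change on the oxygen gives a 50-fold higher number from compound 1 to compound 2 (1.70 log units; beyond the scatter). Compound 3 stands at the limit of > 10000 nM in this assay, at which 1 of the 3 values shown sits. The second change on that oxygen gives an at least 92-fold higher number from compound 1 to compound 3 (1.96 log units; beyond the scatter), and the comparison of the two replacements gives an at least 1.8-fold higher number from compound 2 to compound 3 (0.27 log units; that floor lies within the scatter).

Compound 4 `COc1cc(-c2nnc3c(OC4COC4)cc(-c4ccc5c(ccn5C)c4)cn23)cc(OC)c1OC` differs from compound 2 in one place: methyl in place of hydrogen on an aromatic nitrogen. This is methyl in place of hydrogen on an aromatic nitrogen, turning 1H-indol-5-yl into 1-methyl-1H-indol-5-yl. Going by the values given here, no measured step changes this place. The large steps all concern the group on the oxygen, so they fix only the starting level of compound 2 at 5370 nM and say nothing of size or direction here. No step beyond the scatter is therefore expected in this assay, and the expected change is a 1.2-fold lower number from compound 2 to compound 4 (0.08 log units; within the scatter). The estimated value for compound 4 is 4500 nM, with an expected range of 1500 nM to 10000 nM.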

Compound 4, half-maximal inhibitory concentration: 1290 nM
The estimate for compound 4 lay 3.5-fold (0.54 log units) above the measured number; measured number outside the range, below it.
By their numbers in this assay, from the lowest: compound 1; then compound 4; then compound 2. At a limit, above all of these: compound 3.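

In this assay, methyl in place of hydrogen on the aromatic nitrogen, turning 1H-indol-5-yl into 1-methyl-1H-indol-5-y1, gives a 4.2-fold lower number from compound 2 to compound 4 (0.62 log units; beyond the scatter). Going by these compounds alone, this is the first step outside the group on the oxygen, so this nitrogen is a second place where the read-out moves, and with the oxetan-3-yl group in place, the hydrogen on it is not needed for inhibition. No data given here account for the step.

The compounds shown leave open whether the same methyl gives a similar step on compound 1, with its methyl on the oxygen, or on compound 3. Also open, as far as these compounds go, is how that nitrogen responds to something larger than methyl, such as a longer alkyl chain, an acetyl group or a chain ending in an amine.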